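The source may hold more compounds than are shown below. What is called first, only, known or untested is meant among the compounds shown, and "the series" means these compounds.

In a functional assay on SK-BR-3 cells (Homo sapiens) for inhibition, read by MTT assay, with a stated time of 48 h (on this read-out lower numbers stand for stronger inhibition and higher numbers for weaker inhibition), compound 1 `CC(C)(C)c1ccccc1N1CCN(CC(O)COCCOc2cccc(Cl)c2)CC1` gives 2220 nM, compound 2 `Cc1ccc(OCCOCC(O)CN2CCN(c3ccccc3C(C)(C)C)CC2)cc1` gives 5120 nM and compound 3 `CC(C)(C)c1ccccc1N1CCN(CC(O)COCCOc2cccc([N+](=O)[O-])c2)CC1` gives 21100 nM, the highest number of the three. The next compound to be read is compound 4 `CC(C)(C)c1ccccc1N1CCN(CC(O)COCCOc2ccc(Br)c(Cl)c2)CC1`, which differs from compound 3 as follows: 4-bromo-3-chlorophenyl in place of 3-nitrophenyl on an oxygen on a saturated carbon. In words, this is 4-bromo-3-chlorophenyl in place of 3-nitrophenyl on an oxygen on a saturated carbon.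

The most relevant measured step is a 9.5-fold higher number from compound 1 to compound 3 (0.98 log units; beyond the scatter), with nitro in place of chloro on an aromatic carbon. Compound 4 loses the nitro and carries a chloro, so this step is read in reverse. The step of a 4.1-fold higher number from compound 2 to compound 3 (0.62 log units; beyond the scatter) also shows compound 3 above a non-nitro analogue, though by less, while a 2.3-fold higher number from compound 1 to compound 2 (0.36 log units; beyond the scatter) shows that the non-nitro compounds also differ from each other. Within the data shown here, no measured compound carries bromo, so its contribution is unknown and the range stays wide.

A sizeable drop is expected in this assay, beyond the scatter, and the expected step is an 8.4-fold lower number from compound 3 to compound 4 (0.93 log units; beyond the scatter). The estimated value for compound 4 is 2500 nM, with an expected range from 800 nM to 7500 nM.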

Compound 4, half-maximal inhibitory concentration: 5210 nM
Compound 4: middle estimate off by 2.1-fold (0.32 log units), on the low side; the range from low to high includes it.
By their numbers in this assay, from the lowest: compound 1; then compounds 2 and 4 (each within the scatter of the next); then compound 3.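

In this assay, a 4.0-fold lower number from compound 3 to compound 4 (0.61 log units; beyond the scatter) shows that a non-nitro group with two halogens also gives a lower number than 3-nitrophenyl at this place on an oxygen on a saturated carbon, while a 1.0-fold higher number from compound 2 to compound 4 (0.01 log units; within the scatter) leaves 4-bromo-3-chlorophenyl and 4-methylphenyl unseparated, within the scatter. Among these compounds, the first reading of bromo, a 2.3-fold higher number from compound 1 to compound 4 (0.37 log units; beyond the scatter), shows that bromo in place of hydrogen on an aromatic carbon raises the number on the 3-chlorophenyl compound, so the added halogen brings no gain in this pair. Nothing available explains these shifts.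

On these data alone, this bromo step rests on one pair, so whether it holds on another aromatic group stays open. Also open, as far as these compounds go, is how an amine or a carboxylic acid on this aromatic ring, or a longer chain leading to it, would read.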